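The source may report more compounds than this note shows. Statements on the series, on what has been measured and on what is new or still open speak of the compounds shown alone.

Measured so far: compound 2 `O=c1c(CSC(=S)N2CCOCC2)coc2cc(Cl)ccc12` with 6200 nM; compound 3 `O=c1c(CSC(=S)N2CCOCC2)coc2ccccc12` with 12000 nM; compound 1 `COc1ccc2oc(CSC(=S)N(C(C)C)C(C)C)cc(=O)c2c1` with 19100 nM, all in a functional assay on LM7 cells (Homo sapiens) for antiproliferative activity, read by MTT assay, with a stated time of 72 h; on this read-out higher numbers stand for weaker inhibition and lower numbers for stronger inhibition.

Compound 2 sits within the scatter of compound 3, the step of a 1.9-fold higher number from compound 2 to compound 3 (0.29 log units; within the scatter), and its gap to compound 1 is beyond the scatter. Compound 4 `O=c1c(CSC(=S)N2CCCC2)coc2cc(Cl)ccc12` is not yet measured. It differs from compound 2 by pyrrolidin-1-yl in place of morpholin-4-yl on a thiocarbonyl carbon. Going by the values given here, no measured step bears on this change: the only single-point step known concerns the chloro, and compound 1 differs in several places at once. With nothing to point either way, no step beyond the scatter is expected for compound 4 in this assay, so the estimate is a 1.0-fold higher number from compound 2 to compound 4 (0.02 log units; within the scatter). Compound 4 is therefore estimated at 6500 nM, expected between 2500 nM and 17000 nM.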

Compound 4, half-maximal inhibitory concentration: 2600 nM
Estimate against measurement, compound 4: 2.5-fold (0.40 log units) above, and the stated range covers the measured number.
By their numbers in this assay, from the lowest: compound 4; then compounds 2, 3 and 1 (each within the scatter of the next, the first and the last beyond it).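

With the chloro core held fixed, the group on the thiocarbonyl carbon matters in this assay: pyrrolidin-1-yl in place of morpholin-4-yl gives a 2.4-fold lower number from compound 2 to compound 4 (0.38 log units; beyond the scatter), a modest step and the only one at this position. The change alters ring size and removes the ring oxygen together, so these two differences cannot be separated here. No measurement at hand accounts for the step. As far as these compounds go, whether piperidin-1-yl or an open-chain diethylamino group would follow pyrrolidin-1-yl remains open. So does whether the step carries over to the core of compound 3, which lacks the chloro.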